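The source may hold more compounds than are shown below. What is called first, only, known or untested is meant among the compounds shown, and "the series" means these compounds.

In a functional assay on HL-60 cells (Homo sapiens) for inhibition, read by CCK-8 assay, with a stated time of 48 h (on this read-out lower numbers stand for stronger inhibition and higher numbers for weaker inhibition), compound 1 `COc1ccc(NC(=O)NCCNS(=O)(=O)c2ccc(-c3ccccc3OCc3ccccc3)s2)cc1` gives > 50000 nM as a limit of the assay, not a number. Compound 2 `O=S(=O)(NCCNC(=S)Nc1cccc(Cl)c1)c1ccc(-c2ccccc2OCc2ccccc2)s1` also gives only a limit, > 50000 nM in this case. Compound 3 `O=C(NCCNS(=O)(=O)c1ccc(-c2ccccc2OCc2ccccc2)s1)Nc1cc(Cl)cc(Cl)c1` gives 11700 nM as a true number. In compound 4 `COc1ccc(NC(=O)NCCNS(=O)(=O)c2ccc(-c3ccccc3Oc3ccc([N+](=O)[O-])cc3)s2)cc1` 4-nitrophenyl stands in place of benzyl on an oxygen on an aromatic ring (4-nitrophenyl in place of benzyl on an oxygen on an aromatic ring). Among the compounds with values here, no measured step touches that oxygen. The readable steps, an at least 4.2-fold lower number from compound 1 to compound 3 (0.63 log units; beyond the scatter) and an at least 4.2-fold lower number from compound 2 to compound 3 (0.63 log units; beyond the scatter) both, end in 3,5-dichlorophenyl, whereas compound 4 keeps 4-methoxyphenyl. Only a small step to a lower number is therefore expected for compound 4, namely an at least 1.2-fold lower number from compound 1 to compound 4 (0.09 log units; that floor lies within the scatter) in this assay here. Compound 4 is estimated at 40000 nM with an expected range from 15000 nM to 80000 nM and it may well read only as a limit.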

Compound 4, half-maximal inhibitory concentration: > 50000 nM
Compound 4: no number, only a limit; the forecaster's own chance of this, stated with the estimate: 55%; middle value at least 1.2-fold (0.09 log units) from the limit.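

In this assay compound 4 gives > 50000 nM, a limit and not a number. Within the data shown here, no step from compound 1 to compound 4 can be read, because both stop at the same limit: the limit of > 50000 nM in this assay, at which 3 of the 4 values shown sit. The compounds shown leave open whether 4-nitrophenyl in place of benzyl changes the read-out at all, and in which direction.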